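The compounds below may be only part of what the source reports. "The series", "measured", "known", "first", "only" and "open" are said of these compounds alone.

Compound 1 `CC(C)(C)C1=NN(c2cccc(F)c2)C(c2ccc(O)cc2)C1` sits at the top of the two numbers gathered so far. In an assay on isolated protein for inhibition of protein kinase C zeta type (Homo sapiens), with a stated time of 4 min, tested at 62.5 uM (on this read-out higher numbers stand for more inhibition at the one concentration tested (going by the name of the read-out) and lower numbers for less inhibition), compound 1 gives 98.1%, while the nearest measured neighbour, compound 2 `CC(C)(C)C1=NN(c2ccc(Cl)cc2)C(c2ccc(Br)cc2)C1`, reaches only 39% in this assay, a gap well beyond the scatter of repeated runs. Among the measured compounds shown here, no step between two measured compounds that differ in a single place has been recorded, so nothing directly tells how a lone exchange of one aryl group moves this read-out.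

Compound 3 `CC(C)(C)C1=NN(c2ccc(O)cc2)C(c2ccc(O)cc2)C1` is the next to be tested. It keeps the shared core of compound 1 and changes one group: 4-hydroxyphenyl in place of 3-fluorophenyl on an amine nitrogen in a ring. Because compound 1 already stands at 98.1%, there is little room left to rise, and the read-out is a percentage at a single concentration. The step of a number 10.1 percentage points lower from compound 1 to compound 3 (beyond the scatter) is therefore expected to be small, with no change beyond the scatter, or at most a modest fall. Compound 3 is estimated to give 88% in this assay, within a range from 60% to 100%.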

Compound 3, a percentage reported as inhibition, at one concentration (the size of the read-out at that concentration, not a potency): 40.9%
Beside the measured number, compound 3's estimate is 47.1 percentage points above it, outside the stated range (below it).
By their numbers in this assay, from the lowest: compounds 2 and 3 (each within the scatter of the next); then compound 1.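

In this assay, the group on an amine nitrogen in a ring proves to matter a great deal: exchanging 3-fluorophenyl for 4-hydroxyphenyl gives a step of a number 57.2 percentage points lower from compound 1 to compound 3 (beyond the scatter). Both groups have 7 heavy atoms and one six-membered aromatic ring of carbon only, so this large step comes without any change in those counts; the exchange instead replaces fluorine with oxygen and brings in 1 hydrogen-bond donor and 1 hydrogen-bond acceptor. Nothing measured here explains the loss of inhibition.

This single pair changes both the kind of atom on the aryl ring and where it sits, leaving open which of the two matters; a 3-hydroxyphenyl or a 4-fluorophenyl group on this nitrogen would help separate them. Also open, as far as these compounds go, is how a plain phenyl group, or a phenyl ring carrying a methoxy group or an amine, would behave at this position, and each reading remains a result at one concentration rather than a potency.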